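Dropping One Chloro Group from a Shared Core

The source may report more compounds than this note shows. Statements on the series, on what has been measured and on what is new or still open speak of the compounds shown alone.

Of the compounds shown here, three have been tested in a functional assay on UO-31 cells (Homo sapiens) for cytotoxicity, read by sulforhodamine B assay, with a stated time of 48 h; on this read-out lower numbers stand for stronger inhibition of growth and higher numbers for weaker inhibition of growth. Compound 3 `ClCc1cccc(Cn2cnc3c(Cl)nc(Cl)nc32)c1` gives 1580 nM, and compound 1 `ClCc1cccc(Cn2cnc3c(Cl)ncnc32)c1` gives 1440 nM; the change between them, (hydrogen in place of chloro on an aromatic carbon), produced a step of a 1.1-fold lower number from compound 3 to compound 1 (0.04 log units; within the scatter). Compound 2 `ClCc1ccc(Cn2cnc3nc(Cl)nc(Cl)c32)cc1` gives 1440 nM in this assay, which is level with compound 1 and within the scatter of compound 3. Compound 2 and compound 3 have the same atoms joined differently, and the difference between the two cores is not broken down here.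

Compound 4 `ClCc1ccc(Cn2cnc3ncnc(Cl)c32)cc1` has not yet been measured. It differs from compound 2 by hydrogen in place of chloro on an aromatic carbon, the same change that was made from compound 3 to compound 1. The step from compound 2 to compound 4 in this assay is expected to be a 1.1-fold lower number from compound 2 to compound 4 (0.04 log units; within the scatter), because a 1.1-fold lower number from compound 3 to compound 1 (0.04 log units; within the scatter) was within the scatter. Compound 4 is therefore estimated at 1300 nM, with a likely range from 600 nM to 2800 nM.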

Compound 4, concentration for 50% growth inhibition: 4780 nM
The estimate for compound 4 lay 3.7-fold (0.57 log units) below the measured number; measured number above the stated range.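

On the core of compound 2, hydrogen in place of chloro on an aromatic carbon gives a 3.3-fold higher number from compound 2 to compound 4 (0.52 log units; beyond the scatter) in this assay, which is a modest step. In these two pairs the outcome of the same change depends on the core: the same change on two cores in this assay, a 1.1-fold lower number (0.04 log units; within the scatter) from compound 3 to compound 1 and a 3.3-fold higher number (0.52 log units; beyond the scatter) from compound 2 to compound 4, 3.6-fold (0.56 log units) apart, beyond the scatter of two such steps

The step therefore cannot be carried as a fixed amount from one core to the other, but the data do not show why the two cores differ, and two pairs set no rule for any further core.

The compounds shown carry only chloro or hydrogen at this place. As far as these compounds go, how an amine or a methoxy group there would read in this assay on either core remains open.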